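Bromochromene thiazolidinone series: methyl on the saturated ring carbon

A few compounds are considered here, and "the series" means these few. Any claim that something is new, unique, unknown or untested is made for them only; others in the source may bear on it.

In a functional assay on A549 cells (Homo sapiens) for antiproliferative activity, read by MTT assay, with a stated time of 72 h (a higher number here means a weaker inhibitor, a lower number a stronger inhibitor), compound 1 `O=C1NC(=O)/C(=C/C2=Cc3cc(Br)ccc3OC2)S1` gives 79500 nM, and compound 3 `CC1Oc2ccc(Br)cc2C=C1/C=C1\SC(=O)NC1=O` gives 65500 nM. The change between them is methyl in place of hydrogen on a saturated ring carbon, and the step it made is a 1.2-fold lower number from compound 1 to compound 3 (0.08 log units; within the scatter). Compound 2 `O=C1NC(=S)S/C1=C\C1=Cc2cc(Br)ccc2OC1` gives 51000 nM in this assay; the difference between the core of compound 2 and the core of compound 1 is not broken down here. Compound 4 `CC1Oc2ccc(Br)cc2C=C1/C=C1\SC(=S)NC1=O` carries the same change relative to compound 2, namely (methyl in place of hydrogen on a saturated ring carbon), at the same place as in the earlier pair. The expected step in this assay is a 1.1-fold lower number from compound 2 to compound 4 (0.05 log units; within the scatter). Among the compounds with values here, this rests on the one earlier step of this kind, a 1.2-fold lower number from compound 1 to compound 3 (0.08 log units; within the scatter), which lay within the scatter, so little movement is expected. Compound 4 is accordingly estimated at 45000 nM, with a range from 24000 nM to 90000 nM.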

Compound 4, half-maximal inhibitory concentration: 47500 nM
Compound 4: middle estimate off by 1.1-fold (0.02 log units), on the low side; low and high end bracket the measured number.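

In this assay, methyl in place of hydrogen on a saturated ring carbon gives a 1.1-fold lower number from compound 2 to compound 4 (0.03 log units; within the scatter), and the two cores show no readable difference in this step: the same change on two cores in this assay, a 1.2-fold lower number (0.08 log units; within the scatter) from compound 1 to compound 3 and a 1.1-fold lower number (0.03 log units; within the scatter) from compound 2 to compound 4, 1.1-fold (0.05 log units) apart, within the scatter of two such steps. Both steps lie within the scatter, so the change leaves the number effectively in place on both cores, and no gain is being carried from one core to the other. Two pairs with one small group do not show that a step large enough to read would transfer in the same way, or that this would hold on other cores.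

Open, as far as these compounds go, is whether a longer chain, an amine or a carboxylic acid at this ring carbon would move the number beyond the scatter, and whether any such step would match on both cores.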